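This account rests on a few compounds, and the source may have more. Where it says the series, first, only, none or still open, it means among the compounds named here.

Compound 3 `CCNC(=O)Nc1ccc(S(=O)(=O)Oc2ccccc2C(C)C)cc1` gives the lowest number among the three compounds measured in a functional assay on M21 cells (Homo sapiens) for antiproliferative activity, read by sulforhodamine B assay, with a stated time of 48 h (a lower number here means a stronger inhibitor, a higher number a weaker inhibitor), where compound 3 gives 4700 nM. Compound 1 `CC(=O)Nc1ccc(S(=O)(=O)Oc2ccccc2C(C)C)cc1` gives 21000 nM and compound 2 `CCC(=O)Nc1ccc(S(=O)(=O)Oc2ccccc2C(C)C)cc1` gives 11000 nM; the steps of a 4.5-fold lower number from compound 1 to compound 3 (0.65 log units; beyond the scatter) and a 2.3-fold lower number from compound 2 to compound 3 (0.37 log units; beyond the scatter) set compound 3 apart from both. Compound 4 `CCCCCNC(=O)Nc1ccc(S(=O)(=O)Oc2ccccc2C(C)C)cc1` differs from compound 3 by propyl in place of hydrogen on a saturated chain carbon, two bonds along the chain from an amide-type nitrogen. Of the measured steps, only the chain lengthening a 1.9-fold lower number from compound 1 to compound 2 (0.28 log units; within the scatter) resembles this change, and it stayed within the scatter. Within the data shown here, no measured step tests a chain of this length on the amide-type nitrogen. The expectation is therefore a step of a 1.6-fold lower number from compound 3 to compound 4 (0.19 log units; within the scatter) in this assay, small and at most modest toward a lower number. Compound 4 is expected to give 3000 nM, with a range from 1200 nM to 9000 nM.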

Compound 4, half-maximal inhibitory concentration: 4600 nM
The estimate for compound 4 lay 1.5-fold (0.19 log units) below the measured number; low and high end bracket the measured number.
By their numbers in this assay, from the lowest: compounds 4 and 3 (each within the scatter of the next); then compounds 2 and 1 (each within the scatter of the next).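

With a 1.0-fold lower number from compound 3 to compound 4 (0.01 log units; within the scatter) in this assay, ethylamino and pentylamino cannot be told apart, so at this position the added propyl shows no effect beyond the scatter. The longer chain keeps the distance from the two compounds with a carbon-bound carbonyl, with a 2.4-fold lower number from compound 2 to compound 4 (0.38 log units; beyond the scatter) and a 4.6-fold lower number from compound 1 to compound 4 (0.66 log units; beyond the scatter). No evidence on hand bears on this result. What the compounds shown leave open is whether a still longer chain, a branched chain, or a chain ending in an amine or a carboxylic acid would move the number beyond the scatter.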